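Nitro substitution on the compound 2 scaffold

The compounds below may be only part of what the source reports. "The series", "measured", "known", "first", "only" and "open" are said of these compounds alone.

Of the compounds shown here, three have been measured in a functional assay on HCT-116 cells (Homo sapiens) for cytotoxicity, read by MTT assay; a higher number here means a weaker inhibitor, a lower number a stronger inhibitor. Compound 1 `COc1ccc2c(c1)CCC/C2=N\NCc1nc2cc([N+](=O)[O-])ccc2[nH]1` gives 45000 nM. Compound 2 `CC1=NN(Cc2nc3ccccc3[nH]2)C(=O)C1` gives 42000 nM in this assay. Compound 3 `O=C1c2ccccc2C(=O)N1NCc1nc2ccccc2[nH]1` gives 31000 nM in this assay. Going by the values given here, all three numbers lie within the usual scatter of one another, so compound 2 cannot be placed above or below compound 1 or compound 3 on these data; the series so far is flat and weak. None of the three pairs differs in a single place, so no step can be read from them.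

Compound 4 `CC1=NN(Cc2nc3cc([N+](=O)[O-])ccc3[nH]2)C(=O)C1` is the next compound to be measured in this assay. Relative to compound 2, the change is nitro in place of hydrogen on an aromatic carbon. Among the compounds with values here, the only compound already carrying a nitro group is compound 1, and its number of 45000 nM does not stand apart from the nitro-free compounds, which is the sole guide available. On that basis no step beyond the scatter is expected from compound 2 to compound 4, in either direction. The estimated value for compound 4 in this assay is 40000 nM, with a range of 15000 nM to 100000 nM, and the expected step is a 1.1-fold lower number from compound 2 to compound 4 (0.02 log units; within the scatter).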

Compound 4, half-maximal inhibitory concentration: 200000 nM
The estimate for compound 4 lay 5.0-fold (0.70 log units) below the measured number; the measured number lies above the stated range.
By their numbers in this assay, from the lowest: compounds 3, 2 and 1 (each within the scatter of the next); then compound 4.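

In this assay, going by these compounds alone, the position is not indifferent to substitution: nitro in place of hydrogen on an aromatic carbon of the six-membered aromatic ring of carbon only gives a 4.8-fold higher number from compound 2 to compound 4 (0.68 log units; beyond the scatter), a modest loss and the first step to lie beyond the scatter. Compound 1 also carries a nitro group, but it differs from compound 4 in more than one place, so its number says nothing about this change, and the loss is established only on the scaffold of compound 2. Within the data shown here, nothing measured so far accounts for the higher number of compound 4.

From the compounds shown here alone, with a single substituent at this aromatic carbon, it remains open whether the loss is specific to nitro or would also follow from a group such as an amine, a methoxy group, a chlorine atom or a carboxylic acid on the same carbon. Going by these compounds, it is equally open whether nitro at this place would produce a comparable step on the core of compound 3, where a matched pair would allow the change to be read on a second scaffold.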